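Clearance series: aryl amide variation on the shared core

The compounds below may be only part of what the source reports. "The series", "measured", "known", "first", "only" and "open" are said of these compounds alone.

Compound 2 `Cc1cccc(NC(=O)[C@H]2CN(C)C[C@@H]2c2ccc(/C=C/C(=O)Nc3ccccc3N)cc2)c1` gives 14 mL/min/kg in an in vitro ADME assay on microsomes from liver (Homo sapiens) for pharmacokinetics, read by LC-MS, with a stated time of 10 min, tested at 1 uM; a higher number here means faster removal of the compound, a lower number slower removal. Compound 1 `CN1C[C@H](C(=O)Nc2cccc(Cl)c2)[C@@H](c2ccc(/C=C/C(=O)Nc3ccccc3N)cc2)C1` gives 7 mL/min/kg and compound 3 `CN1C[C@H](C(=O)Nc2ccccc2F)[C@@H](c2ccc(/C=C/C(=O)Nc3ccccc3N)cc2)C1` gives 10 mL/min/kg; the three numbers sit within the usual scatter of one another, as a 2.0-fold higher number from compound 1 to compound 2 (0.30 log units; within the scatter) and a 1.4-fold lower number from compound 2 to compound 3 (0.15 log units; within the scatter) show. Compound 4 `CN1C[C@H](C(=O)Nc2ccc(Cl)cn2)[C@@H](c2ccc(/C=C/C(=O)Nc3ccccc3N)cc2)C1` differs from compound 2 by 5-chloropyridin-2-yl in place of 3-methylphenyl on an amide-type nitrogen. Within the data shown here, the steps that bear on this exchange of the group on the amide-type nitrogen are a 1.4-fold lower number from compound 2 to compound 3 (0.15 log units; within the scatter) and a 2.0-fold higher number from compound 1 to compound 2 (0.30 log units; within the scatter), neither beyond the scatter. Among the measured compounds shown here, no step to a pyridinyl group has been measured, so the expectation for compound 4 is a step of a 1.2-fold lower number from compound 2 to compound 4 (0.07 log units; within the scatter), within the scatter. Compound 4 is therefore estimated at 12 mL/min/kg, between 6 mL/min/kg and 24 mL/min/kg.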

Compound 4, clearance: 13 mL/min/kg
Compound 4: middle estimate off by 1.1-fold (0.03 log units), on the low side, within the range that was stated.
By their numbers in this assay, from the lowest: compounds 1, 3, 4 and 2 (each within the scatter of the next).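

The 5-chloropyridin-2-yl group is the only ring here on the amide-type nitrogen with a hetero atom, and it gives no step beyond the scatter (a 1.1-fold lower number from compound 2 to compound 4 (0.03 log units; within the scatter)), (a 1.3-fold higher number from compound 3 to compound 4 (0.11 log units; within the scatter)) and (a 1.9-fold higher number from compound 1 to compound 4 (0.27 log units; within the scatter)). At this position, clearance therefore does not separate this ring from the three substituted phenyl groups. Nothing available explains this result.

From the compounds shown here alone, the separate contributions of the ring nitrogen and the chlorine remain open. Also open, going by these compounds, is whether a carboxylic acid or dimethylamino group on this ring, or a saturated piperidine ring in its place, would give a step beyond the scatter.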